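Swapping the Side Group: Expecting Little Change

A few compounds are considered here, and "the series" means these few. Any claim that something is new, unique, unknown or untested is made for them only; others in the source may bear on it.

Among the compounds with values here, in an assay on isolated protein for inhibition of tyrosine-protein kinase Fes/Fps (Homo sapiens), read by HTRF, tested at 10 uM (a higher number here means more inhibition at the concentration tested (going by the name of the read-out), a lower number less inhibition), compound 1 `Clc1ccc2sc(CN3CCN(c4ncnc5c4CN(Cc4ccccc4)CC5)CC3)cc2c1` gives 6%, one of two numbers so far and within the scatter of the other. Compound 2 `O=C(CN1CCN(c2ncnc3c2CN(Cc2ccccc2)CC3)CC1)Nc1cc(F)ccc1F` gives 11%, and the step of a number 5 percentage points higher from compound 1 to compound 2 (within the scatter) shows that exchanging the group on the saturated chain carbon bound to the ring amine nitrogen left the read-out essentially where it was. Compound 3 `Cc1cc(C(=O)N2CCN(c3ncnc4c3CN(Cc3ccccc3)CC4)CC2)c(C)n1C` carries a different replacement: (1,2,5-trimethyl-1H-pyrrol-3-yl)carbonyl in place of (5-chloro-1-benzothiophen-2-yl)methyl on an amine nitrogen in a ring. Within the data shown here, only the step from compound 1 to compound 2 bears on this change, and it was within the scatter, so no step beyond the scatter is expected in this assay. The estimate for compound 3 is 8%, between -4% and 20%, an expected step of a number 2 percentage points higher from compound 1 to compound 3 (within the scatter).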

Compound 3, a percentage reported as inhibition, at one concentration (the size of the read-out at that concentration, not a potency): 0%
For compound 3 the middle estimate is 8 percentage points above the measured one, and the stated range covers the measured number.
By their numbers in this assay, from the lowest: compounds 3, 1 and 2 (each within the scatter of the next, the first and the last beyond it).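

On the amine nitrogen in a ring, (1,2,5-trimethyl-1H-pyrrol-3-yl)carbonyl in place of (5-chloro-1-benzothiophen-2-yl)methyl gave, in this assay, a number 6 percentage points lower from compound 1 to compound 3 (within the scatter). The number therefore stayed level with a carbonyl on that nitrogen and the loss of the six-membered aromatic ring of carbon only, with no step beyond the scatter. No measurement on hand gives a reason for this result. On these data alone, whether a group bearing a carboxylic acid or a primary amine on that nitrogen would move the read-out beyond the scatter remains open.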